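Trifluoromethyl to nitro at the solubility limit

The compounds below may be only part of what the source reports. "The series", "measured", "known", "first", "only" and "open" are said of these compounds alone.

Measured in a physicochemical assay for solubility, in phosphate buffer, at pH 7.4 (a lower number here means a less soluble compound, a higher number a more soluble compound), all three results are limits rather than numbers:
- compound 1 `CCOC(=O)c1c(-c2ccc(OC)cc2)[nH]c2cccc(OC)c2c1=O` gives > 100000 nM
- compound 2 `CCOC(=O)c1c(-c2cccc(OC)c2)[nH]c2cccc(OC)c2c1=O` gives > 100000 nM
- compound 3 `CCOC(=O)c1c(-c2cccc(C(F)(F)F)c2)[nH]c2cccc(OC)c2c1=O` gives > 100000 nM

As far as these compounds go, compound 3 holds only a limit, so its exact place is unknown: it stands at the limit of > 100000 nM in this assay, at which 3 of the 3 values shown sit. The next compound, compound 4 `CCOC(=O)c1c(-c2cccc([N+](=O)[O-])c2)[nH]c2cccc(OC)c2c1=O`, carries one change: nitro in place of trifluoromethyl on an aromatic carbon. Nitro replaces trifluoromethyl on an aromatic carbon, meta to a large group.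

For the measured compounds named here, two measured steps bear on this. The closer is a step that the two limits leave unreadable from compound 2 to compound 3, and the other is a step that the two limits leave unreadable from compound 1 to compound 2. Neither has a readable size, so they suggest no direction. The estimated step is a number no higher from compound 3 to compound 4 (the limit leaves the size open), and none beyond the scatter is expected in this assay. For compound 4 the expected value is 100000 nM (range 50000 nM to 200000 nM).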

Compound 4, solubility: 49000 nM
Estimate against measurement, compound 4: 2.0-fold (0.31 log units) above; the measured number lies below the stated range.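

Compound 4 is the first compound in this assay to give a measured number rather than a limit, so nitro at this position brings the series into readable range: the limit of > 100000 nM in this assay, at which 3 of the 4 values shown sit.

The readings are an at least 2.0-fold lower number from compound 3 to compound 4 (0.30 log units; that floor lies within the scatter), an at least 2.0-fold lower number from compound 2 to compound 4 (0.30 log units; that floor lies within the scatter) and an at least 2.0-fold lower number from compound 1 to compound 4 (0.30 log units; that floor lies within the scatter). Each is only a floor, so the real drop may be larger, or no larger than the scatter.

As far as these compounds go, the steps among compound 1, compound 2 and compound 3 cannot be read, so the order of these three stays unknown. Also open, from the compounds shown here alone, is how an amine or a carboxylic acid in the same place would read in this assay.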